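Pyridine amidine thiosemicarbazides: piperidine replaced by morpholine

This account rests on a few compounds, and the source may have more. Where it says the series, first, only, none or still open, it means among the compounds named here.

Measured so far:
compound 1 `Cc1cccc(/C(N)=N/NC(=S)N2CCCCC2)n1`: 43%
compound 2 `N/C(=N\NC(=S)N1CCCCCC1)c1ccccn1`: 76.5%

Within the data shown here, in a functional assay on MCF7 cells (Homo sapiens) for cytotoxicity, read by MTT assay, with a stated time of 72 h, tested at 30 uM (a higher number here means more inhibition of growth at the concentration tested, a lower number less inhibition of growth), compound 1 gives 43%, the lower of the two numbers known; compound 2 gives 76.5%, a gap beyond the usual scatter. The two differ in more than one place, so nothing further is drawn from that pair.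

Compound 3 `Cc1cccc(/C(N)=N/NC(=S)N2CCOCC2)n1` carries morpholin-4-yl in place of piperidin-1-yl on a thiocarbonyl carbon. Among the measured compounds shown here, no step between measured compounds matches this change, so the expectation rests on compound 1 alone: a small step, downward if any, most likely within the scatter, expected as a number 5 percentage points lower from compound 1 to compound 3 (within the scatter). Compound 3 is therefore estimated at 38%, in a range from 20% to 58%.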

Compound 3, percent growth inhibition at one concentration: 57.8%
Estimate against measurement, compound 3: 19.8 percentage points below; measured number inside the range.
By their numbers in this assay, from the lowest: compound 1; then compound 3; then compound 2.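

On the thiocarbonyl carbon, the position was not tied to piperidin-1-yl: in this assay, morpholin-4-yl in its place gives a number 14.8 percentage points higher from compound 1 to compound 3 (beyond the scatter). The change adds a ring oxygen and a hydrogen-bond acceptor with the heavy-atom count unchanged, and growth inhibition rises rather than falls on the core of compound 1. Nothing available explains this step.

Still open, as far as these compounds go, is how thiomorpholin-4-yl or 4-methylpiperazin-1-yl would compare on the same thiocarbonyl carbon. Also open, from the compounds shown here alone, is whether morpholin-4-yl gives a similar step on the core of compound 2.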